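Cyclohexyl carbamate series: removing the butyl substituent

This account rests on a few compounds, and the source may have more. Where it says the series, first, only, none or still open, it means among the compounds named here.

Compound 3 `CCCCC1CCC(OC(=O)N[C@@H](CC(C)C)C(=O)N[C@@H](C[C@@H]2CCNC2=O)C(O)S(=O)(=O)O)CC1` gives 59100 nM in a toxicity assay on Huh-7 cells (Homo sapiens) for cytotoxicity (on this read-out lower numbers stand for higher toxicity in this test and higher numbers for lower toxicity in this test), the lowest of the two numbers shown, though its nearest neighbour sits within the scatter. That neighbour, compound 2 `CCCCC1CCC(OC(=O)N[C@@H](CC(C)C)C(=O)N[C@H](C=O)C[C@@H]2CCNC2=O)CC1`, gives 63300 nM in this assay. Compound 1 `O=C[C@H](C[C@@H]1CCNC1=O)NC(=O)[C@H](CC1CCCCC1)NC(=O)c1cc2ccccc2[nH]1` reaches only the assay limit of > 100000 nM in this assay. Among the compounds with values here, the single measured step, a 1.1-fold lower number from compound 2 to compound 3 (0.03 log units; within the scatter), concerns hydroxy(sulfo)methyl in place of formyl and leaves the ring untouched. Compound 4 `CC(C)C[C@H](NC(=O)OC1CCCCC1)C(=O)N[C@@H](C[C@@H]1CCNC1=O)C(O)S(=O)(=O)O`, not yet measured, differs from compound 3 by hydrogen in place of butyl on a saturated ring carbon. Within the data shown here, no measured step covers a change of this kind, so no step beyond the scatter in this assay is expected. Compound 4 is therefore expected to give 75000 nM (range 35000 nM to 150000 nM), an expected step of a 1.3-fold higher number from compound 3 to compound 4 (0.10 log units; within the scatter).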

Compound 4, half-maximal cytotoxic concentration: > 100000 nM
Compound 4 gave a limit, no number; the forecaster's own chance of this, stated with the estimate: 30%; middle value at least 1.3-fold (0.12 log units) from the limit.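

Hydrogen in place of butyl on a saturated ring carbon is the first change at this ring position, and it reads as an at least 1.6-fold higher number from compound 3 to compound 4 (0.22 log units; that floor lies within the scatter). In this assay compound 4 gives > 100000 nM, which is a limit and not a number, so the true size of the step cannot be read. Loss of the butyl brings no lower number here, and the read-out gives no resolution at its top end: the limit of > 100000 nM in this assay, at which 2 of the 4 values shown sit.

From the compounds shown here alone, how an ethyl or an amine on this ring carbon would read in this assay stays open. Going by these compounds, the formyl partner of compound 4 also stays open.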